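Working notes: methyl for fluoro on the aromatic ring

The source may hold more compounds than are shown below. What is called first, only, known or untested is meant among the compounds shown, and "the series" means these compounds.

Compound 1 `O=C(O)C1=Cc2ccccc2OC1(OCc1cc(-c2ccc(F)cc2)no1)C(F)(F)F`: 64200 nM
Compound 2 `CCOC(=O)C1=Cc2ccccc2OC1(OCc1cc(-c2ccc(F)cc2)no1)C(F)(F)F`: 48200 nM

Of the compounds shown here, two have been measured in a functional assay on MCF7 cells (Homo sapiens) for inhibition, read by MTT assay, with a stated time of 24 h; a higher number here means a weaker inhibitor, a lower number a stronger inhibitor. Compound 1 gives 64200 nM, the highest of the two numbers; its nearest neighbour, compound 2, gives 48200 nM, and the step of a 1.3-fold lower number from compound 1 to compound 2 (0.12 log units; within the scatter) lies within the scatter, so the two cannot be ordered.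

Compound 3 `Cc1ccc(-c2cc(COC3(C(F)(F)F)Oc4ccccc4C=C3C(=O)O)on2)cc1` is not yet measured. It differs from compound 1 by methyl in place of fluoro on an aromatic carbon. Among the measured compounds shown here, the only measured step lies elsewhere in the molecule, at the carboxylic acid end, and was small; nothing measured so far touches the six-membered aromatic ring or gives a direction for a change there. The expectation is therefore no step beyond the scatter for compound 3, a 1.1-fold lower number from compound 1 to compound 3 (0.03 log units; within the scatter). Compound 3 is estimated at 60000 nM, with a range from 25000 nM to 150000 nM.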

Compound 3, half-maximal inhibitory concentration: 30100 nM
The estimate for compound 3 lay 2.0-fold (0.30 log units) above the measured number; the range from low to high includes it.
By their numbers in this assay, from the lowest: compounds 3, 2 and 1 (each within the scatter of the next, the first and the last beyond it).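

In this assay, the change from 4-fluorophenyl to 4-methylphenyl gives a 2.1-fold lower number from compound 1 to compound 3 (0.33 log units; beyond the scatter). The substituent on this aromatic carbon, para to a large group, therefore registers in the read-out, whereas the earlier step, elsewhere in the molecule, stayed within the scatter. Among the compounds shown here, with the carboxylic acid kept, methyl in place of fluoro gives a modestly stronger inhibitor, and this single pair is the only basis for that reading. Nothing available explains the shift in the number.

As far as these compounds go, whether a chloro group, a methoxy group or an amine on this aromatic carbon would move the number further remains open. So does whether the same change would carry over to the ethyl ester, compound 2, or hold in a cell line other than MCF7.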